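The compounds below may be only part of what the source reports. "The series", "measured", "known", "first", "only" and "open" are said of these compounds alone.

Compound 1 `O=C(O)CC[C@H](NC(=O)CN(c1nc(Cl)nc2[nH]cnc12)C1CC1)C(=O)O`: 29.5%
Compound 2 `NC(=O)CC[C@H](NC(=O)CN(c1nc(Cl)nc2[nH]cnc12)C1CC1)C(=O)O`: 11.4%

In a functional assay on the whole organism (Tail, strain ICR) with Mus musculus as the target, in the tail flick test, with a stated time of 150 min, at a dose of 25 umol/kg by the oral route (on this read-out higher numbers stand for a stronger effect at the one dose given and lower numbers for a weaker effect), compound 2 gives the lowest of the two numbers; its nearest neighbour is compound 1, reached by the step of a number 18.1 percentage points lower from compound 1 to compound 2 (beyond the scatter). Compound 3 `C[C@H](NC(=O)CN(c1nc(Cl)nc2[nH]cnc12)C1CC1)C(=O)O` differs from compound 2 by hydrogen in place of carbamoylmethyl on a saturated chain carbon, two bonds along the chain from an amide-type nitrogen and a carbonyl carbon. Within the data shown here, no measured step shows this change; the only step known, from an acid to an amide on that side chain, was modest, and the removal of the whole carbamoylmethyl group is a different kind of change. A step near the scatter is expected, a number 3.6 percentage points higher from compound 2 to compound 3 (within the scatter). For compound 3 the estimate in this assay is 15%, between 3% and 35%.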

Compound 3, a percentage reported as activity, at one dose (the size of the read-out at that dose, not a potency): 14.7%
Estimate against measurement, compound 3: 0.3 percentage points above, within the range that was stated.
By their numbers in this assay, from the lowest: compounds 2 and 3 (each within the scatter of the next); then compound 1.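

In this assay, hydrogen in place of carbamoylmethyl on this saturated chain carbon makes no change beyond the scatter (a number 3.3 percentage points higher from compound 2 to compound 3 (within the scatter)). Hydrogen in place of carboxymethyl on the same carbon does (a number 14.8 percentage points lower from compound 1 to compound 3 (beyond the scatter)), so among these compounds only the carboxymethyl of compound 1 stands apart, while compound 2 and compound 3 do not separate. Nothing available explains this. As far as these compounds go, what an amine at the end of this side chain would give stays open, as does the effect of a longer chain carrying the carboxylic acid.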